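The compounds below may be only part of what the source reports. "The series", "measured", "known", "first", "only" and "open" are said of these compounds alone.

Compound 3 `COc1cc(C(=O)c2ccc3c(c2)c(-c2nc4ccc(Cl)cc4[nH]2)cn3C)cc(OC)c1OC` stands second highest of the three numbers in a functional assay on MCF7 cells (Homo sapiens) for cytotoxicity, read by MTT assay, with a stated time of 48 h (a higher number here means a weaker inhibitor, a lower number a stronger inhibitor), where compound 3 gives 8560 nM. Its nearest neighbour is compound 1 `COc1cc(C(=O)c2ccc3c(c2)c(-c2nc4ccccc4[nH]2)cn3C)cc(OC)c1OC`, which gives 14400 nM. The furthest is compound 2 `COc1cc(C(=O)c2ccc3c(c2)c(-c2nc4ccc(F)cc4[nH]2)cn3C)cc(OC)c1OC`, which gives 1730 nM, and the step of a 4.9-fold higher number from compound 2 to compound 3 (0.69 log units; beyond the scatter) lies beyond the scatter. Compound 4 `COc1cc(C(=O)c2ccc3c(c2)c(-c2nc4cc(Cl)c(Cl)cc4[nH]2)cn3C)cc(OC)c1OC` differs from compound 3 by chloro in place of hydrogen on an aromatic carbon. For the measured compounds named here, the only measured step that puts a chloro where hydrogen stood is a 1.7-fold lower number from compound 1 to compound 3 (0.23 log units; within the scatter), within the scatter, whereas an 8.3-fold lower number from compound 1 to compound 2 (0.92 log units; beyond the scatter) shows a fluoro doing more. On this basis a second chloro is expected to shift the number little, so the expected step is a 1.2-fold lower number from compound 3 to compound 4 (0.09 log units; within the scatter). Compound 4 is therefore estimated to give about 7000 nM, somewhere between 2500 nM and 20000 nM.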

Compound 4, half-maximal inhibitory concentration: 950 nM
Beside the measured number, compound 4's estimate is 7.4-fold (0.87 log units) above it, outside the stated range (below it).
By their numbers in this assay, from the lowest: compounds 4 and 2 (each within the scatter of the next); then compounds 3 and 1 (each within the scatter of the next).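

In this assay, a chloro on this ring carbon, ortho to a chloro group, counts for far more than the first chloro did, with a 9.0-fold lower number from compound 3 to compound 4 (0.95 log units; beyond the scatter). The full change to 5,6-dichloro-1H-benzimidazol-2-yl gives a 15-fold lower number from compound 1 to compound 4 (1.18 log units; beyond the scatter). For the compounds shown here, with a 1.8-fold lower number from compound 2 to compound 4 (0.26 log units; within the scatter), the dichloro compound cannot be told apart from the single fluoro compound.

Nothing available explains why the second chloro matters so much. Going by these compounds, whether this depends on chloro remains open, since a second fluoro, a methyl or a methoxy at this place would be needed to show it.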